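Swapping an Aminophenyl for a Difluorophenyl on a Chalcone

The source may hold more compounds than are shown below. What is called first, only, known or untested is meant among the compounds shown, and "the series" means these compounds.

Compound 1, `COc1cc(-c2cc(/C=C/C(=O)c3ccc(N)cc3)[nH]n2)cc(OC)c1OC`, was tested in a functional assay on SK-MEL-2 cells (Homo sapiens) for cytotoxicity, read by sulforhodamine B assay, with a stated time of 48 h, tested at 10 uM; a higher number here means a weaker effect of the compound at the concentration tested, a lower number a stronger effect. In this assay compound 1 gives -15%. Its companion, compound 2, `COc1ccc(-c2cc(/C=C/C(=O)c3cc(OC)c(OC)c(OC)c3)[nH]n2)cc1OC`, gives -12%, and the two values sit within the usual scatter of one another, so neither can be called the stronger of the pair. Both numbers lie near zero, which means that at the concentration used neither compound reduced cell growth to any clear degree.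

Compound 3, `COc1cc(-c2cc(/C=C/C(=O)c3ccc(F)c(F)c3)[nH]n2)cc(OC)c1OC`, has not yet been measured. It differs from compound 1 in one place: 3,4-difluorophenyl in place of 4-aminophenyl on a carbonyl carbon. Going by the values given here, no measured pair shows this particular exchange, so there is no precedent to lean on. Given that compound 1 gives -15%, the expectation is a step of a number 7 percentage points higher from compound 1 to compound 3 (within the scatter), that is, nothing beyond the scatter in either direction. Compound 3 is therefore estimated at -8%, with a range from -25% to 15%.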

Compound 3, a percentage reported as activity, at one concentration (the size of the read-out at that concentration, not a potency): -28%
For compound 3 the middle estimate is 20 percentage points above the measured one; measured number outside the range, below it.
By their numbers in this assay, from the lowest: compound 3; then compounds 1 and 2 (each within the scatter of the next).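

In this assay, placing 3,4-difluorophenyl in place of 4-aminophenyl on the carbonyl carbon gives a number 13 percentage points lower from compound 1 to compound 3 (beyond the scatter). Going by these compounds alone, this is the first sign that the group at this position can change the read-out, with the lower number pointing to a stronger effect at the concentration tested. The exchange also takes away the hydrogen-bond donor and acceptor counted for 4-aminophenyl and brings in two fluorines, but no measurement here shows which of these differences, if any, accounts for the step.

Still open, going by these compounds, is whether both fluorines are needed, a question that plain phenyl or 4-fluorophenyl at the same place could help answer. A single concentration also leaves open how the compounds would compare in potency.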